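The source may report more compounds than this note shows. Statements on the series, on what has been measured and on what is new or still open speak of the compounds shown alone.

Compound 1 `Cc1nc(C)c([C@H](OC(C)(C)C)C(=O)O)c(N2CCC(C)(C)CC2)c1-c1ccc(-c2ccccc2)cc1`: in a toxicity assay on MT2 cells (Homo sapiens) for cytotoxicity, read by XTT assay, with a stated time of 4 days (a lower number here means that less compound is tolerated, a higher number that more compound is tolerated), compound 1 gives >= 20000 nM, which is a limit of the assay and not a number.
Compound 2 `COc1ccc(CCOc2ccc(-c3c(C)nc(C)c([C@H](OC(C)(C)C)C(=O)O)c3N3CCC(C)(C)CC3)cc2)cc1`: in this assay compound 2 gives >= 33500 nM, again a limit rather than a number.

Compound 2 thus stands at the upper edge of what this assay reports, and both values shown are limits, as the limit of >= 20000 nM in this assay, at which 1 of the 2 values shown sits, and the limit of >= 33500 nM in this assay, at which 1 of the 2 values shown sits, record. Within the data shown here, the only step between measured compounds, a step that the two limits leave unreadable from compound 1 to compound 2, cannot be read for size for the same reason given by the limit of >= 20000 nM in this assay, at which 1 of the 2 values shown sits, and (the limit of >= 33500 nM in this assay, at which 1 of the 2 values shown sits).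

Compound 3 `COc1cccc(CCOc2ccc(-c3c(C)nc(C)c([C@H](OC(C)(C)C)C(=O)O)c3N3CCC(C)(C)CC3)cc2)c1` is not yet measured. It differs from compound 2 as 3-methoxyphenyl in place of 4-methoxyphenyl on a saturated chain carbon, two bonds along the chain from an oxygen on an aromatic ring. Among the measured compounds shown here, no measured step bears on this change with a readable size. In this assay no step beyond the scatter is expected from compound 2 to compound 3, so the estimated step is a number no higher from compound 2 to compound 3 (the limit leaves the size open). Compound 3 is expected to give 33500 nM, within 15000 nM to 70000 nM, most likely reported once more as a limit.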

Compound 3, half-maximal cytotoxic concentration: >= 33500 nM
Compound 3: a limit, no number; the forecaster's own chance of this, stated with the estimate: 80%; the middle value lies on the limit itself.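

In this assay compound 3 gives >= 33500 nM, a limit and not a number. The steps from compound 3 to compound 1 and compound 2 therefore cannot be read for size. Still open, as far as these compounds go, is where the half-maximal cytotoxic concentrations of all three compounds lie, and whether 3-methoxyphenyl in place of 4-methoxyphenyl changes them at all.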